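Moving the Methyl on the Benzyl Arm: Cytotoxicity Outlook

The source may hold more compounds than are shown below. What is called first, only, known or untested is meant among the compounds shown, and "the series" means these compounds.

Measured so far:
compound 1, `Clc1ccc(NCc2cncn2Cc2ccc(-c3ccccc3)cc2)cc1-c1ccccc1`: > 1000 nM
compound 2, `COC(=O)c1ccc(NCc2cncn2Cc2ccccc2C)cc1-c1ccccc1`: 10000 nM

In a toxicity assay on NIH3T3 cells (Mus musculus) for cytotoxicity, read by resazurin assay (on this read-out lower numbers stand for an effect already at smaller amounts and higher numbers for an effect only at larger amounts of compound), compound 2 gives 10000 nM. Within the data shown here, this is the only plain number in this assay. For compound 1 the result is a limit of the assay, > 1000 nM. Among the measured compounds shown here, that limit is the only other value shown, so the limit of > 1000 nM in this assay, at which 1 of the 2 values shown sits, is all the evidence that stands beside compound 2, and no pair of measured compounds differing in one place exists to calibrate any step.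

Compound 3, `COC(=O)c1ccc(NCc2cncn2Cc2cccc(C)c2)cc1-c1ccccc1`, differs from compound 2 by 3-methylphenyl in place of 2-methylphenyl on a saturated chain carbon bound to an aromatic nitrogen. The same atoms are present in both, joined differently. For the measured compounds named here, with no measured step to lean on, a change of this kind is expected to produce no shift beyond the usual scatter in this assay.

Compound 3 is therefore estimated at 10000 nM, between 4000 nM and 25000 nM, an expected step of no change at the digits printed from compound 2 to compound 3 (within the scatter).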

Compound 3, half-maximal effective concentration: > 10000 nM
Compound 3: only a limit was reported; the forecaster's own chance of this, stated with the estimate: 30%; the middle value lies on the limit itself.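

Among these compounds, this pair gives the first step between compounds that differ in one place: in this assay, exchanging 2-methylbenzyl for 3-methylbenzyl gives a number no lower from compound 2 to compound 3 (the limit leaves the size open). On a saturated chain carbon bound to an aromatic nitrogen, therefore, this rearrangement of the same atoms does not bring the effect to smaller amounts of compound. Its size cannot be read because the result for compound 3 is a limit and not a number: the limit of > 10000 nM in this assay, at which 1 of the 3 values shown sits.

The compounds shown leave open how far the value of compound 3 lies from that of compound 2, and so whether moving the methyl changes the read-out at all. They also leave open how this assay would respond to an aminomethyl group or a carboxylic acid in place of the methyl on this benzyl arm.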